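The source may report more compounds than this note shows. Statements on the series, on what has been measured and on what is new or still open speak of the compounds shown alone.

Of the compounds shown here, three sharing one core have been measured in a functional assay on B16-F10 cells (Mus musculus) for antiproliferative activity, read by MTT assay, with a stated time of 48 h; on this read-out higher numbers stand for weaker inhibition and lower numbers for stronger inhibition. Compound 1 `CC(=O)N1N=C(c2ccc3ccccc3c2)OC1c1ccccc1Br` gives 6.98 ug/mL in this assay, the highest of the three numbers, so it is the weakest inhibitor among them. Compound 2 `CC(=O)N1N=C(c2ccc3ccccc3c2)OC1c1cccnc1` gives 3.06 ug/mL, and compound 3 `CC(=O)N1N=C(c2ccc3ccccc3c2)OC1c1ccncc1` gives 2.97 ug/mL. The step of a 2.3-fold lower number from compound 1 to compound 2 (0.36 log units; beyond the scatter) and the step of a 2.4-fold lower number from compound 1 to compound 3 (0.37 log units; beyond the scatter) are both modest, while the step of a 1.0-fold lower number from compound 2 to compound 3 (0.01 log units; within the scatter) lies within the scatter. Compound 4 `CC(=O)N1N=C(c2ccc3ccccc3c2)OC1c1ccc(C)cc1` has not yet been measured in this assay. It differs from compound 1 at one place: 4-methylphenyl in place of 2-bromophenyl on a saturated ring carbon. The two measured steps away from compound 1 both swap the 2-bromophenyl for pyridin-3-yl or pyridin-4-yl, and both lowered the number modestly; the 4-methylphenyl of compound 4 is an aromatic ring of carbon only, so whether the same gain follows is uncertain. For compound 4 the expected step is a 1.4-fold lower number from compound 1 to compound 4 (0.14 log units; within the scatter), a small move toward a lower number if any. The estimate for compound 4 is 5 ug/mL, with a range from 2.5 ug/mL to 12 ug/mL.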

Compound 4, half-maximal inhibitory concentration: 3.85 ug/mL
Compound 4: the middle estimate sits 1.3-fold (0.11 log units) above what was measured; measured number inside the range.
By their numbers in this assay, from the lowest: compounds 3, 2, 4 and 1 (each within the scatter of the next, the first and the last beyond it).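

In this assay, for the compounds shown here, the earlier compounds left open whether a ring nitrogen set the two pyridine compounds apart from compound 1, and the 4-methylphenyl group, with only carbon in its ring, gives a 1.3-fold higher number from compound 3 to compound 4 (0.11 log units; within the scatter) and a 1.3-fold higher number from compound 2 to compound 4 (0.10 log units; within the scatter) so no need for that nitrogen shows at this saturated ring carbon. The swap for 2-bromophenyl gives a 1.8-fold lower number from compound 1 to compound 4 (0.26 log units; within the scatter) so compound 4 cannot be told apart from compound 1 either, even though compound 1 and compound 3 differ beyond the scatter. Nothing available here accounts for these numbers. A plain phenyl ring would help show whether the bromine, the methyl or the place of either on the ring counts, since compound 4 changes both the group and its place at once. The compounds shown also leave open how an amine or a carboxylic acid on this ring would read.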